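The source may report more compounds than this note shows. Statements on the series, on what has been measured and on what is new or still open speak of the compounds shown alone.

Measured so far:
compound 1, `Cc1ccc(C(=O)NNC(=S)Nc2csc(-c3ccccc3)c2)cc1`: in a functional assay on A549 cells (Homo sapiens) for inhibition, read by colorimetric assay and MTT assay, with a stated time of 72 h (on this read-out lower numbers stand for stronger inhibition and higher numbers for weaker inhibition), compound 1 gives 40000 nM
compound 2, `Cc1ccc(C(=O)NNC(=S)Nc2csc(-c3ccc(C)cc3)c2)cc1`: in this assay compound 2 gives 37000 nM
compound 3, `COc1cc(C(=O)NNC(=S)Nc2csc(-c3ccccc3)c2)cc(OC)c1OC`: in this assay compound 3 gives 39000 nM

From compound 1 to compound 2 the change is methyl in place of hydrogen on an aromatic carbon and the result was a 1.1-fold lower number from compound 1 to compound 2 (0.03 log units; within the scatter). The difference between the core of compound 1 and the core of compound 3 is not broken down here; the two values lie within the scatter of each other. Compound 4, `COc1cc(C(=O)NNC(=S)Nc2csc(-c3ccc(C)cc3)c2)cc(OC)c1OC`, is not yet measured; it differs from compound 3 by methyl in place of hydrogen on an aromatic carbon, the same change as before, at the same kind of place.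

In this assay the expected step is a 1.1-fold lower number from compound 3 to compound 4 (0.03 log units; within the scatter), set beside the earlier one because the same change gave a 1.1-fold lower number from compound 1 to compound 2 (0.03 log units; within the scatter). Compound 4 is therefore estimated at 36000 nM, expected between 18000 nM and 72000 nM.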

Compound 4, half-maximal inhibitory concentration: 39000 nM
Estimate against measurement, compound 4: 1.1-fold (0.03 log units) below, within the range that was stated.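

In this assay, methyl in place of hydrogen on the aromatic carbon gives no change at the digits printed from compound 3 to compound 4 (within the scatter). The two steps agree across the two cores: the same change on two cores in this assay, a 1.1-fold lower number (0.03 log units; within the scatter) from compound 1 to compound 2 and no change at the digits printed (within the scatter) from compound 3 to compound 4, 1.1-fold (0.03 log units) apart, within the scatter of two such steps. This shows that phenyl to 4-methylphenyl carries from the core of compound 1 to the core of compound 3 without a step beyond the scatter, but neither step is itself beyond the scatter, so the agreement is only between two null results and does not show that a change with a measurable step would carry over in the same way.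

The compounds shown hold only hydrogen or methyl at this place. From the compounds shown here alone, whether an amine, a carboxylic acid or a longer chain there would move the number on either core remains open.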